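A Nitro Group Swapped In on an Inactive Series

A few compounds are considered here, and "the series" means these few. Any claim that something is new, unique, unknown or untested is made for them only; others in the source may bear on it.

Compound 1 `Cc1c(O)c(C)c2c(c1O)C(=O)CC(c1ccccc1O)O2`, compound 2 `Cc1c(O)c(C)c2c(c1O)C(=O)CC(c1cccc(O)c1)O2` and compound 3 `Cc1c(O)c(C)c2c(c1O)C(=O)CC(c1ccccc1Cl)O2` share one core and differ in the groups on one aromatic ring. In a functional assay on VSMC cells (Rattus norvegicus) (on this read-out higher numbers stand for weaker inhibition and lower numbers for stronger inhibition), compound 1 is reported as "not active" (no number reported), with no number given. Compound 2 is also reported as "not active" (no number reported), again without a number. Compound 3 gives > 20000 nM, which is a limit and not a number. None of the three therefore offers a measured potency to build on.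

Compound 4 `Cc1c(O)c(C)c2c(c1O)C(=O)CC(c1ccccc1[N+](=O)[O-])O2` keeps the core of compound 3 and changes one group: nitro in place of chloro on an aromatic carbon. This puts nitro in place of chloro on an aromatic carbon, ortho to a large group. Among the measured compounds shown here, no measured pair in this assay shows how large such a change can be, so no step beyond the scatter is expected, in either direction. This expectation rests on compound 3, whose > 20000 nM is a limit. The estimated change is a number no higher from compound 3 to compound 4 (the limit leaves the size open). Compound 4 is expected to give about 20000 nM, with an estimated range from 7000 nM to 60000 nM.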

Compound 4, half-maximal inhibitory concentration: 9900 nM
Compound 4: middle estimate off by 2.0-fold (0.31 log units), on the high side, within the range that was stated.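

Among the compounds shown here, compound 4 is the first compound to give a single number in this assay, showing that this aromatic carbon can carry nitro and still return a measurable value. Compound 3 stands at > 20000 nM, which is a limit and not a number. Nitro in place of chloro therefore gives an at least 2.0-fold lower number from compound 3 to compound 4 (0.30 log units; that floor lies within the scatter), and the true size of the step stays open, as the comparison rests on this value: the limit of > 20000 nM in this assay, at which 1 of the 4 values shown sits.

The compounds shown leave open whether a different group on this aromatic carbon, such as an amine, a carboxylic acid or a methoxy group, would give a lower number than nitro does. They also leave open how nitro would read on another carbon of the same aromatic ring.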